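Swapping Methylsulfanyl for Propyl on Compound 1

The compounds below may be only part of what the source reports. "The series", "measured", "known", "first", "only" and "open" are said of these compounds alone.

Measured compounds:
compound 1 `CCOC(=O)C1=C(C)NC(=S)NC1c1ccc(SC)cc1` gives 8.5 ug/mL
compound 2 `CCOC(=O)C1=C(C)NC(=S)NC1C1CCCCC1` gives 2.2 ug/mL
compound 3 `CCOC(=O)C1=C(C)NC(=S)NC1c1cccc(OC)c1` gives 1.3 ug/mL

These three share one core and were tested in a functional assay on OVCAR-3 cells (Homo sapiens) for inhibition, read by sulforhodamine B assay, with a stated time of 48 h; on this read-out lower numbers stand for stronger inhibition of growth and higher numbers for weaker inhibition of growth. Compound 1 gives the highest number of the three, so its inhibition of growth is the weakest here; compound 2 and compound 3 both give lower numbers, and both gaps lie beyond the usual scatter.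

Compound 4 `CCCc1ccc(C2NC(=S)NC(C)=C2C(=O)OCC)cc1` has not yet been measured. It differs from compound 1 by propyl in place of methylsulfanyl on an aromatic carbon. For the measured compounds named here, no measured pair shows this change, so nothing in the data fixes its direction. The step of a 1.5-fold lower number from compound 1 to compound 4 (0.19 log units; within the scatter) is expected to be modest, leaning toward a lower number but possibly within the scatter. Compound 4 is expected to give 5.5 ug/mL, in a range from 1.8 ug/mL to 17 ug/mL.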

Compound 4, concentration for 50% growth inhibition: 38.1 ug/mL
The estimate for compound 4 lay 6.9-fold (0.84 log units) below the measured number; measured number above the stated range.
By their numbers in this assay, from the lowest: compounds 3 and 2 (each within the scatter of the next); then compound 1; then compound 4.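

At the aromatic carbon para to a large group, propyl in place of methylsulfanyl is no neutral exchange: in this assay it gives a 4.5-fold higher number from compound 1 to compound 4 (0.65 log units; beyond the scatter) and so weaker inhibition of growth. For the compounds shown here, this is the first pair here that differs in one place, and it shows that the group at this position can shift the number beyond the scatter. Nothing available explains the direction of this step.

From the compounds shown here alone, how an amine or a longer chain such as butyl would behave at this position remains open. A single pair also cannot show whether the same change would act alike on another core.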